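Amide nitrogen substituents: tert-butyl against halophenyl

The source may report more compounds than this note shows. Statements on the series, on what has been measured and on what is new or still open speak of the compounds shown alone.

Measured compounds in a functional assay on MDA-MB-231 cells (Homo sapiens) for antiproliferative activity, read by MTT assay, with a stated time of 72 h; on this read-out lower numbers stand for stronger inhibition and higher numbers for weaker inhibition:
compound 1 `CC(C)(C)NC(=O)CCc1cccc2c1B(O)OC2`: > 100000 nM
compound 2 `O=C(CCc1cccc2c1B(O)OC2)Nc1ccc(Cl)cc1`: 3600 nM
compound 3 `O=C(CCc1cccc2c1B(O)OC2)Nc1ccc(I)cc1`: 33000 nM

Compound 1 stands at the limit of > 100000 nM in this assay, at which 1 of the 3 values shown sits. That value is a limit of the assay and not a number, so every step away from compound 1 is known only as a minimum. The two aryl amides lie clearly lower: an at least 27-fold lower number from compound 1 to compound 2 (1.44 log units; beyond the scatter), and an at least 3.0-fold lower number from compound 1 to compound 3 (0.48 log units; beyond the scatter). Between the two aryl amides themselves, a 9.2-fold higher number from compound 2 to compound 3 (0.96 log units; beyond the scatter), so the chloro compound sits well below the iodo compound.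

Compound 4 `O=C(CCc1cccc2c1B(O)OC2)Nc1cccc(I)c1` differs from compound 1 by 3-iodophenyl in place of tert-butyl on an amide-type nitrogen. The steps from compound 1 to compound 2 and from compound 1 to compound 3 both bear on it, and both go the same way, a lower number beyond the scatter; the closest measured relative is compound 3, which carries iodine on the same ring. A number somewhere between the two aryl amides is the working expectation. Compound 4 is therefore expected to give 15000 nM, with a range from 3000 nM to 60000 nM. The estimate for compound 4 means an at least 6.6-fold lower number from compound 1 to compound 4 (0.82 log units; beyond the scatter) is expected, a step beyond the scatter.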

Compound 4, half-maximal inhibitory concentration: 5300 nM
Compound 4: middle estimate off by 2.8-fold (0.45 log units), on the high side, and the stated range covers the measured number.
By their numbers in this assay, from the lowest: compounds 2 and 4 (each within the scatter of the next); then compound 3. At a limit, above all of these: compound 1.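

In this assay, going by these compounds alone, replacing tert-butyl with 3-iodophenyl on the amide-type nitrogen gives an at least 18-fold lower number from compound 1 to compound 4 (1.27 log units; beyond the scatter), while 3-iodophenyl in place of 4-iodophenyl gives a 6.2-fold lower number from compound 3 to compound 4 (0.79 log units; beyond the scatter), so the place of the iodine on the phenyl ring changes the number beyond the scatter, a difference the earlier compounds could not show. The change from 4-chlorophenyl to 3-iodophenyl gives a 1.5-fold higher number from compound 2 to compound 4 (0.17 log units; within the scatter), which lies within the scatter, so an iodine on the ring does not in itself go with the higher number of compound 3. Compound 1 is a limit and not a number, and the step from it is known only as a minimum because of this: the limit of > 100000 nM in this assay, at which 1 of the 4 values shown sits.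

The compounds shown leave open whether a chloro group responds to a change of ring place as iodine does, as no chloro compound carries it where compound 4 carries its iodine. Also open, on these data alone, is how the number would move with an amine or a carboxylic acid on the phenyl ring, or with a longer chain leading to the amide carbonyl.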